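The source may report more compounds than this note shows. Statements on the series, on what has been measured and on what is new or still open speak of the compounds shown alone.

In a functional assay (a higher number here means a weaker inhibitor, a lower number a stronger inhibitor), compound 1 `CN(C)c1ccc(C2C(C#N)=C(N)OC(c3c[nH]c4ccccc34)=C2C#N)cc1` gives 900 ug/mL. Compound 2 `N#CC1=C(N)OC(c2c[nH]c3ccccc23)=C(C#N)C1c1ccccc1Cl` gives > 1000 ug/mL, which is a limit and not a number; it stands at the limit of > 1000 ug/mL in this assay, at which 1 of the 2 values shown sits. Compound 3 `N#CC1=C(N)OC(c2c[nH]c3ccccc23)=C(C#N)C1c1ccc(F)cc1` carries 4-fluorophenyl in place of 2-chlorophenyl on a saturated ring carbon, (4-fluorophenyl in place of 2-chlorophenyl on a saturated ring carbon). Among the measured compounds shown here, the one measured step at that ring carbon, an at least 1.1-fold higher number from compound 1 to compound 2 (0.04 log units; that floor lies within the scatter), has a floor within the scatter, so no change beyond the scatter is expected in this assay. The expected step is a number no higher from compound 2 to compound 3 (the limit leaves the size open). The estimated value for compound 3 is 1000 ug/mL, with an expected range of 500 ug/mL to 2000 ug/mL.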

Compound 3, half-maximal inhibitory concentration: 960 ug/mL
The estimate for compound 3 lay 1.0-fold (0.02 log units) above the measured number, and the stated range covers the measured number.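

In this assay, fluoro in place of dimethylamino on an aromatic carbon gives a 1.1-fold higher number from compound 1 to compound 3 (0.03 log units; within the scatter), so this exchange on the phenyl moves the number by nothing beyond the scatter. 4-Fluorophenyl in place of 2-chlorophenyl on the saturated ring carbon gives an at least 1.0-fold lower number from compound 2 to compound 3 (0.01 log units; that floor lies within the scatter). Compound 2 holds a limit and not a number: the limit of > 1000 ug/mL in this assay, at which 1 of the 3 values shown sits.

On these data alone, whether any group on this phenyl can move the number beyond the scatter stays open. A carboxylic acid or a primary amine on the phenyl, or a pyridine ring in its place, would test this.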